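A few compounds are considered here, and "the series" means these few. Any claim that something is new, unique, unknown or untested is made for them only; others in the source may bear on it.

Compound 1, `COC(=O)Cn1cc(CNC(=O)c2cnc(Nc3ccc(C#N)cc3)cc2Oc2c(C)cc(C)cc2C)nn1`, in an ADME assay on MT4 cells (Homo sapiens) for cytotoxicity, read by MTT assay, with a stated time of 5 days; a lower number here means that less compound is tolerated, a higher number that more compound is tolerated: 13800 nM.
Compound 2, `Cc1cc(C)c(Oc2cc(Nc3ccc(C#N)cc3)ncc2C(=O)NCc2cn(CCCO)nn2)c(C)c1`, in this assay: 25200 nM.

For the measured compounds named here, compound 2 holds the higher of the two numbers, though the sole measured step, a 1.8-fold higher number from compound 1 to compound 2 (0.26 log units; within the scatter), lies within the scatter. Compound 3, `Cc1cc(C)c(Oc2cc(Nc3ccc(C#N)cc3)ncc2C(=O)NCc2cn(Cc3ccccc3F)nn2)c(C)c1`, differs from compound 2 by 2-fluorophenyl in place of 2-hydroxyethyl on a saturated chain carbon bound to an aromatic nitrogen. Going by the values given here, no measured step covers this exchange; the one step known at this place stayed within the scatter, so no shift beyond the scatter is expected in this assay. Compound 3 is therefore estimated at 18000 nM, with a range from 7000 nM to 45000 nM. That amounts to an expected step of a 1.4-fold lower number from compound 2 to compound 3 (0.15 log units; within the scatter).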

Compound 3, half-maximal cytotoxic concentration: > 222000 nM
Compound 3: no number, only a limit (the forecaster's own chance of this, stated with the estimate: 15%); middle value at least 12-fold (1.09 log units) from the limit.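

In this assay, the position on a saturated chain carbon bound to an aromatic nitrogen can move the number beyond the scatter, which the earlier pair did not show: 2-fluorophenyl gives an at least 8.8-fold higher number from compound 2 to compound 3 (0.94 log units; beyond the scatter), and an at least 16-fold higher number from compound 1 to compound 3 (1.20 log units; beyond the scatter). More compound is tolerated with this group than with either earlier one. Compound 3 holds only a limit, not a number: the limit of > 222000 nM in this assay, at which 1 of the 3 values shown sits.

From the compounds shown here alone, how far compound 3 lies past its limit stays open. Also open, going by these compounds, is whether the ring or its fluorine accounts for the step, which a plain benzyl group or a chain ending in an amine could test.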